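Swapping the Aryl Ether Substituent: Expected Acid Dissociation

This account rests on a few compounds, and the source may have more. Where it says the series, first, only, none or still open, it means among the compounds named here.

Of the compounds shown here, two sharing one core have been measured in a physicochemical assay for acid dissociation. Compound 1 `COc1ccc(F)cc1CNCCCNc1ccnc2cc(-c3cccc4ccccc34)ccc12` gives 9.47, and compound 2 `COc1ccc(F)cc1CNCCCNc1ccnc2cc(Oc3ccc(Cl)cc3)ccc12` gives 9.28. Compound 2 stands lowest of the two numbers, but its nearest neighbour is compound 1 with a number 0.19 log units lower from compound 1 to compound 2 (within the scatter), so the two cannot be told apart. That measured step, 4-chlorophenoxy in place of naphthalen-1-yl on an aromatic carbon, is the only one available, and it altered the very same outer part of the molecule that is now altered again. Compound 3 `COc1ccc(F)cc1CNCCCNc1ccnc2cc(Oc3cccc(N(C)C)c3)ccc12` is the unmeasured compound: 3-(dimethylamino)phenyl in place of 4-chlorophenyl on an oxygen on an aromatic ring. Going by the values given here, since the single measured step at this outer position stayed within the scatter, the step to compound 3 is expected to stay within the scatter as well, with no direction to be read from it, which is a number 0.07 log units higher from compound 2 to compound 3 (within the scatter). For compound 3 the estimated value in this assay is therefore 9.35, expected to lie between 9 and 9.7.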

Compound 3, acid dissociation constant: 9.28
For compound 3 the middle estimate is 0.07 log units above the measured one; low and high end bracket the measured number.
By their numbers in this assay, from the lowest: compounds 2, 3 and 1 (each within the scatter of the next).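

In this assay, the outer aryl group on the oxygen can take on a nitrogen-bearing substituent without a readable effect: 3-(dimethylamino)phenyl in place of 4-chlorophenyl gives no change at the digits printed from compound 2 to compound 3 (within the scatter) and so cannot be told apart from the chlorine-bearing compound. This exchange goes beyond the earlier one, since the entering group brings a nitrogen and a hydrogen-bond acceptor, and the comparison with the directly attached naphthalen-1-yl group gives a number 0.19 log units lower from compound 1 to compound 3 (within the scatter) as well, so all three compounds now sit within the scatter of one another and the three outer groups do not separate in this read-out. No supporting information is available to explain this result.

Going by these compounds alone, these three compounds show only that the number stays put for these particular outer groups, and they cannot say how far that holds for other substituents. A carboxylic acid on the outer ring, or a longer chain between that ring and the oxygen, remains an open case, as does any exchange in the rest of the shared core.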